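Trading a carboxy group for a nitrile on the shared core

The compounds below may be only part of what the source reports. "The series", "measured", "known", "first", "only" and "open" are said of these compounds alone.

Compound 3 `COc1ccc2c(c1)OC(c1cc(OC)c(OC)c(OC)c1)C(C(=O)O)=C2` carries a carboxy group on the shared core. In a functional assay for inhibition of nuclear factor NF-kappa-B complex (Homo sapiens) (a lower number here means a stronger inhibitor, a higher number a weaker inhibitor), compound 3 gives only a limit, > 50000 nM. Compound 1 `COc1ccc2c(c1)OC(c1cc(OC)c(OC)c(OC)c1)C(C(=O)N1CCCCC1)=C2` also gives only a limit in this assay, > 50000 nM. Going by the values given here, compound 2 `COC(=O)C1=Cc2ccc(OC)cc2OC1c1cc(OC)c(OC)c(OC)c1` gives 13800 nM, the one finite number of the three, and the step of an at least 3.6-fold higher number from compound 2 to compound 3 (0.55 log units; beyond the scatter) shows that uncapping the ester weakens inhibition measurably, while a step that the two limits leave unreadable from compound 1 to compound 3 cannot be sized. Compound 3 thus sits among the weakest values shown; the limit of > 50000 nM in this assay, at which 2 of the 3 values shown sit, marks where it stands. Compound 4 `COc1ccc2c(c1)OC(c1cc(OC)c(OC)c(OC)c1)C(C#N)=C2` differs by cyano in place of carboxy on a double-bonded ring carbon. Since the nearest measured step, an at least 3.6-fold higher number from compound 2 to compound 3 (0.55 log units; beyond the scatter), was at least modest, a modest gain is expected, roughly an at least 2.5-fold lower number from compound 3 to compound 4 (0.39 log units; beyond the scatter). Compound 4 is therefore estimated at 20000 nM in this assay, within 5000 nM to 80000 nM.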

Compound 4, half-maximal inhibitory concentration: 3400 nM
The estimate for compound 4 lay 5.9-fold (0.77 log units) above the measured number; the measured number lies below the stated range.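

On this double-bonded ring carbon, cyano gives a finite number in this assay where carboxy gave only a limit (an at least 14-fold lower number from compound 3 to compound 4 (1.16 log units; beyond the scatter)). Cyano likewise clears the piperidine amide (an at least 14-fold lower number from compound 1 to compound 4 (1.16 log units; beyond the scatter)) and also improves on the methyl ester, the only other finite value (a 4.1-fold lower number from compound 2 to compound 4 (0.61 log units; beyond the scatter)). Compound 1 and compound 3 remain limits, not numbers: the limit of > 50000 nM in this assay, at which 2 of the 4 values shown sit.

On these data alone, whether other groups at this carbon, such as an amine or a longer chain ending in a nitrile, would match cyano stays open. So does whether cyano keeps its gain when the methoxy groups on the shared core change.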